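The compounds below may be only part of what the source reports. "The series", "measured", "known", "first", "only" and "open" are said of these compounds alone.

Compound 1 `O=C1CCc2ccc(OCc3cccc(Cl)c3)cc2N1` was tested in an assay on isolated protein for inhibition of Amine oxidase [flavin-containing] A (Homo sapiens), read by fluorescence, with a stated time of 15 min (a higher number here means a weaker inhibitor, a lower number a stronger inhibitor), where it gives only a limit of the assay, > 100000 nM, and no number. Compound 2 `CC(=O)c1ccc(OCc2cccc(Cl)c2)cc1F` in this assay likewise gives only a limit, > 100000 nM. What the measurements show is the limit of > 100000 nM in this assay, at which 2 of the 2 values shown sit, so neither compound reaches a measurable strength. Compound 3 `O=C1CCc2ccc(OCc3cccc(Br)c3)cc2N1` differs from compound 1 by bromo in place of chloro on an aromatic carbon. Within the data shown here, no measured pair shows how such a change shifts this assay, so no step beyond the scatter is expected. Compound 3 is expected to remain at the limit, with an expected step that the limit leaves unreadable from compound 1 to compound 3. The estimate for compound 3 is 150000 nM, between 50000 nM and 500000 nM.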

Compound 3, half-maximal inhibitory concentration: 49200 nM
For compound 3 the middle estimate is 3.0-fold (0.48 log units) above the measured one, and the stated range ends above it.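

Putting bromo in place of chloro at this place gives an at least 2.0-fold lower number from compound 1 to compound 3 (0.30 log units; that floor lies within the scatter). Compound 3 is thus the only compound shown with a real number in this assay, so this single-atom change is enough to bring a readable value, although the smallest step the data allow is not beyond the usual scatter. The other values remain limits: the limit of > 100000 nM in this assay, at which 2 of the 3 values shown sit.

Still open, from the compounds shown here alone, is how an iodo, methyl or trifluoromethyl group would read at this place. Also open, going by these compounds, is whether bromo would bring a number on the core of compound 2.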